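This account rests on a few compounds, and the source may have more. Where it says the series, first, only, none or still open, it means among the compounds named here.

In a functional assay on ML1 cells (Homo sapiens) for antiproliferative activity, read by WST assay, with a stated time of 3 days (on this read-out lower numbers stand for stronger inhibition and higher numbers for weaker inhibition), compound 1 `Nc1c(F)c(=O)[nH]c(=O)n1[C@@H]1O[C@H](CO)[C@@H](O)[C@H]1O` gives 700 nM and compound 2 `CCc1c(F)c(=O)[nH]c(=O)n1[C@@H]1O[C@H](CO)[C@@H](O)[C@H]1O` gives 2100 nM as the higher of the two numbers. Compound 3 `O=Cc1c(F)c(=O)[nH]c(=O)n1[C@@H]1O[C@H](CO)[C@@H](O)[C@H]1O` carries formyl in place of ethyl on an aromatic carbon in the same place. For the measured compounds named here, only one measured step bears on this place, a 3.0-fold higher number from compound 1 to compound 2 (0.48 log units; beyond the scatter) with ethyl in place of amino, and it is modest. Going by the values given here, no measured compound carries formyl, so no direction is fixed and no step beyond the scatter is expected in this assay here. For compound 3 the estimated value is 1500 nM with an expected range of 350 nM to 6000 nM in this series. The estimate means an expected 1.4-fold lower number from compound 2 to compound 3 (0.15 log units; within the scatter) overall.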

Compound 3, half-maximal inhibitory concentration: 300 nM
Compound 3: middle estimate off by 5.0-fold (0.70 log units), on the high side; measured number outside the range, below it.
By their numbers in this assay, from the lowest: compound 3; then compound 1; then compound 2.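

Formyl gives the lowest number of the three at this aromatic carbon, with a 7.0-fold lower number from compound 2 to compound 3 (0.85 log units; beyond the scatter) and a 2.3-fold lower number from compound 1 to compound 3 (0.37 log units; beyond the scatter). The span at this position is thus wider than amino and ethyl alone showed, and ethyl and formyl, with the same count of heavy atoms, stand at its two ends. Nothing at hand accounts for this order.

Going by these compounds, whether the lower number goes with the carbonyl itself stays open; an acetyl, a carboxylic acid or a hydroxymethyl at this carbon would bear on that. On these data alone, how a longer chain would rank also remains unknown.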